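This account rests on a few compounds, and the source may have more. Where it says the series, first, only, none or still open, it means among the compounds named here.

In a functional assay on Bel7402/5-FU cells (Homo sapiens) for antiproliferative activity, read by MTT assay, with a stated time of 72 h (on this read-out lower numbers stand for stronger inhibition and higher numbers for weaker inhibition), compound 1 `C=C1C(=O)O[C@H]2[C@H]1CC/C(COC(=O)CCC(=O)OCn1cc(F)c(=O)[nH]c1=O)=C\CC[C@@]1(C)O[C@@H]21` gives > 20000 nM, which is a limit of the assay and not a number. For the measured compounds named here, compound 2 `C=C1C(=O)O[C@H]2[C@H]1CC/C(COC(=O)Cn1cc(F)c(=O)n(Cc3ccc(C(F)(F)F)cc3)c1=O)=C\CC[C@@]1(C)O[C@@H]21` gives 2250 nM in this assay, and this is the only true number available. Compound 3 `C=C1C(=O)O[C@H]2[C@H]1CC/C(COC(=O)Cn1cc(F)c(=O)n(Cc3ccc(F)c(F)c3)c1=O)=C\CC[C@@]1(C)O[C@@H]21` has not yet been measured. It differs from compound 2 in one place: 3,4-difluorophenyl in place of 4-(trifluoromethyl)phenyl on a saturated chain carbon bound to an aromatic nitrogen. Here 3,4-difluorophenyl takes the place of 4-(trifluoromethyl)phenyl on a saturated chain carbon bound to an aromatic nitrogen. Going by the values given here, no measured pair shows the effect of this exchange in this assay, so the expectation rests on compound 2 at 2250 nM, and no change beyond the scatter is expected. The estimated step is a 1.3-fold higher number from compound 2 to compound 3 (0.12 log units; within the scatter). For compound 3 the expected value is 3000 nM, with an estimated range from 1000 nM to 9000 nM.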

Compound 3, half-maximal inhibitory concentration: 4480 nM
Beside the measured number, compound 3's estimate is 1.5-fold (0.17 log units) below it; the measured number falls inside the stated range.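

In this assay, placing 3,4-difluorophenyl where 4-(trifluoromethyl)phenyl stood, on a saturated chain carbon bound to an aromatic nitrogen, gives a 2.0-fold higher number from compound 2 to compound 3 (0.30 log units; within the scatter). For the compounds shown here, this is the first pair of measured compounds here that differ in one place, and it shows that the two fluorinated aryl groups cannot be told apart at this position in this read-out. Nothing shown explains why the exchange leaves the result within the scatter.

The compounds shown leave open whether a ring without fluorine, such as plain phenyl, or one carrying a methoxy group, an amine or a carboxylic acid, would keep the result at this level. They also leave open whether a longer chain between the aromatic nitrogen and the ring, or a simple methyl group in place of the whole benzyl group, would change it.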